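Shortening the alkyl chain on a GPR84 agonist scaffold

The source may report more compounds than this note shows. Statements on the series, on what has been measured and on what is new or still open speak of the compounds shown alone.

The measured compounds and their values:
compound 1 `N#CCCCCc1nc(O)cc(O)n1` — > 100000 nM
compound 2 `CC(C)CCCc1nc(O)cc(O)n1` — 2110 nM
compound 3 `CCCCCCCCCc1nc(O)cc(O)n1` — 48.7 nM

In a functional assay on HEK293 cells for agonist activity at G-protein coupled receptor 84 (Homo sapiens), read by calcium flux (on this read-out lower numbers stand for an effect already at smaller amounts and higher numbers for an effect only at larger amounts of compound), compound 3 gives 48.7 nM, the lowest of the two numbers available. Compound 2 gives 2110 nM in this assay, a clearly higher number. The value of compound 1 in this assay is only a limit of > 100000 nM in this assay, at which 1 of the 3 values shown sits, and not a number.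

Compound 4 `CCCCCc1nc(O)cc(O)n1` is reached from compound 3 by hydrogen in place of butyl on a saturated chain carbon, five bonds along the chain from an aromatic carbon. Among the measured compounds shown here, two measured steps concern the same chain: an at least 47-fold lower number from compound 1 to compound 2 (1.67 log units; beyond the scatter) and an at least 2000-fold lower number from compound 1 to compound 3 (3.31 log units; beyond the scatter), both large. Compound 2, which carries a shorter chain than compound 3, also shows a markedly higher number than compound 3. On this basis compound 4, with a chain shorter than either, is expected to give a number higher than compound 3, and the step of a 120-fold higher number from compound 3 to compound 4 (2.09 log units; beyond the scatter) is estimated to lie beyond the scatter. Compound 4 is therefore expected to give about 6000 nM, within a range from 1000 nM to 40000 nM.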

Compound 4, half-maximal effective concentration: 3670 nM
For compound 4 the middle estimate is 1.6-fold (0.21 log units) above the measured one; the range from low to high includes it.
By their numbers in this assay, from the lowest: compound 3; then compounds 2 and 4 (each within the scatter of the next). At a limit, above all of these: compound 1.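

Hydrogen in place of butyl at this place, five bonds along the chain from an aromatic carbon, is a large loss in this assay, a 75-fold higher number from compound 3 to compound 4 (1.88 log units; beyond the scatter); yet hydrogen in place of methyl on a saturated chain carbon bound to two saturated chain carbons leaves no readable difference, a 1.7-fold higher number from compound 2 to compound 4 (0.24 log units; within the scatter). Even the short chain of compound 4 still separates clearly from the nitrile-ended chain, an at least 27-fold lower number from compound 1 to compound 4 (1.43 log units; beyond the scatter). That step rests on a limit rather than a number for compound 1: the limit of > 100000 nM in this assay, at which 1 of the 4 values shown sits.

The compounds shown leave open whether a longer chain than that of compound 3 would bring the number lower still, and at which chain length between compound 4 and compound 3 the drop sets in. They also leave open how an amine or a carboxylic acid at the chain end would read.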